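A few compounds are considered here, and "the series" means these few. Any claim that something is new, unique, unknown or untested is made for them only; others in the source may bear on it.

Measured so far:
- compound 1, `CC(C)CC1OCCC(Cl)=C1[Si](C)(C)C` — 39000 nM
- compound 2, `C[C@@H]1O[C@H](C2CCCCC2)C([Si](C)(C)C)=C(Cl)[C@H]1C` — 84000 nM

Both compounds were tested in a functional assay on WiDr cells (Homo sapiens) for antiproliferative activity; a higher number here means a weaker inhibitor of growth, a lower number a stronger inhibitor of growth. In this assay compound 1 gives 39000 nM and compound 2 gives 84000 nM. Of the two numbers, compound 2 holds the higher one, and the gap to compound 1 lies beyond the usual scatter of repeated measurements, so compound 2 is the weaker growth inhibitor of the pair. Both numbers sit at the weak end of what such an assay can report.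

The next compound, compound 3 with structure `C#CCC[C@H]1O[C@@H](C)[C@H](C)C(Cl)=C1[Si](C)(C)C`, keeps the core of compound 2 with its two methyl groups and chloro group and changes one position: but-3-yn-1-yl in place of cyclohexyl on a saturated ring carbon. Compound 1, which also carries an open chain at the corresponding place, shows the lower number of the two measured compounds, but it differs from compound 2 in more than one place, so no step can be read from it. Among the measured compounds shown here, with no comparable step among the measured compounds, the direction of this change is open. Compound 3 is expected to stay close to compound 2, with a 1.4-fold lower number from compound 2 to compound 3 (0.15 log units; within the scatter) not clearly beyond the scatter. The estimate for compound 3 in this assay is 60000 nM, with a range from 20000 nM to 180000 nM.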

Compound 3, concentration for total growth inhibition: 68000 nM
The estimate for compound 3 lay 1.1-fold (0.05 log units) below the measured number; the range from low to high includes it.
By their numbers in this assay, from the lowest: compounds 1, 3 and 2 (each within the scatter of the next, the first and the last beyond it).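

Among the compounds shown here, this is the first step that can be read on its own at this position, a saturated ring carbon next to the ring oxygen: in this assay, but-3-yn-1-yl in place of cyclohexyl gives a 1.2-fold lower number from compound 2 to compound 3 (0.09 log units; within the scatter), so the assay does not tell these two compounds apart. At this position, then, a ring of six carbons and an open chain of four heavy atoms ending in a triple bond give numbers that are the same within the scatter, even though the two groups differ in size and shape on paper. Nothing measured here explains this result.

On these data alone, what remains open is whether any group at this position can shift the number beyond the scatter, for instance an amine, a carboxylic acid or a much longer carbon chain, since cyclohexyl and but-3-yn-1-yl both have no hydrogen-bond donors or acceptors and no net charge. Compound 1 differs from compound 2 and compound 3 in more than one place, so what sets its number apart from that of compound 2 also stays unresolved.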